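The compounds below may be only part of what the source reports. "The series", "measured", "known", "first", "only" and "open" are said of these compounds alone.

Measured so far in a functional assay on MCF7 cells (Homo sapiens) for inhibition, read by MTT assay, with a stated time of 72 h; a lower number here means a stronger inhibitor, a higher number a weaker inhibitor:
- compound 1 `CC(C)c1ccc(-c2nc(SCc3cn(CC(=O)NC(=O)Nc4ccccn4)nn3)nc(Nc3ccccc3F)c2C#N)cc1` gives > 64000 nM, a limit of the assay rather than a number.
- compound 2 `CC(C)c1ccc(Nc2nc(SCc3cn(CC(=O)NC(=O)Nc4ccccn4)nn3)nc(-c3ccc(C(C)C)cc3)c2C#N)cc1` gives 28600 nM.
- compound 3 `COc1cc(-c2nc(SCc3cn(CC(=O)NC(=O)Nc4ccccn4)nn3)nc(Nc3ccc(C(C)C)cc3)c2C#N)cc(OC)c1OC` gives 30900 nM.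

Compound 3 holds the higher of the two numbers, with compound 2 nearest at a 1.1-fold higher number from compound 2 to compound 3 (0.03 log units; within the scatter), a gap within the scatter. Compound 4 `COc1cc(-c2nc(SCc3cn(CC(=O)NC(=O)Nc4ccccn4)nn3)nc(Nc3ccc(Cl)cc3)c2C#N)cc(OC)c1OC` differs from compound 3 by chloro in place of isopropyl on an aromatic carbon. Of the measured steps, an at least 2.2-fold lower number from compound 1 to compound 2 (0.34 log units; beyond the scatter) also touches the aryl on the amino nitrogen, but starts from a limit (the limit of > 64000 nM in this assay, at which 1 of the 3 values shown sits), so its size is only a bound; a 1.1-fold higher number from compound 2 to compound 3 (0.03 log units; within the scatter) touches the other aryl and is within the scatter. Among the compounds with values here, no measured step exchanges isopropyl for chloro on that ring, so compound 4 is expected to sit close to compound 3 in this assay, with a 1.2-fold higher number from compound 3 to compound 4 (0.07 log units; within the scatter) as the expected step and an estimate of 36000 nM (range 12000 nM to 100000 nM).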

Compound 4, half-maximal inhibitory concentration: 45100 nM
For compound 4 the middle estimate is 1.3-fold (0.10 log units) below the measured one, within the range that was stated.
By their numbers in this assay, from the lowest: compounds 2, 3 and 4 (each within the scatter of the next). At a limit, above all of these: compound 1.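

Chloro in place of isopropyl, on the aromatic carbon para to a large group, now has a reading between two measured numbers in this assay: a 1.5-fold higher number from compound 3 to compound 4 (0.16 log units; within the scatter). Going from 3 heavy atoms to 1 at this carbon therefore leaves the read-out within the scatter, whereas the earlier step touching this aryl gave only a bound. Nothing measured here accounts for the size of this step.

On these data alone, whether an amine or a carboxylic acid at this carbon would give a step beyond the scatter remains open. Also open, as far as these compounds go, is whether chloro reads the same with 4-isopropylphenyl on the other aryl position.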